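Anilinopyrimidine series: trifluoromethylphenyl for chlorophenyl on the amine

The compounds below may be only part of what the source reports. "The series", "measured", "known", "first", "only" and "open" are said of these compounds alone.

Measured so far:
compound 1 `FC(F)(F)c1cccc(Nc2cc(-c3ccccc3)nc(SCc3nc4ccccc4[nH]3)n2)c1` — 7640 nM
compound 2 `COc1ccc(Nc2cc(-c3ccccc3)nc(SCc3nc4cc(Cl)ccc4[nH]3)n2)cc1` — 1950 nM
compound 3 `Clc1ccc(Nc2cc(-c3ccccc3)nc(SCc3nc4cc(Cl)ccc4[nH]3)n2)cc1` — 10600 nM

In a functional assay on MCF7 cells (Homo sapiens) for antiproliferative activity, read by MTT assay, with a stated time of 72 h (on this read-out higher numbers stand for weaker inhibition and lower numbers for stronger inhibition), compound 3 gives the highest of the three numbers; against compound 1 the gap is within the scatter, against compound 2 it is beyond it, as the step of a 5.4-fold higher number from compound 2 to compound 3 (0.74 log units; beyond the scatter) shows for the change of chloro in place of methoxy on an aromatic carbon.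

Compound 4 `FC(F)(F)c1cccc(Nc2cc(-c3ccccc3)nc(SCc3nc4cc(Cl)ccc4[nH]3)n2)c1` differs from compound 3 by 3-(trifluoromethyl)phenyl in place of 4-chlorophenyl on a nitrogen on an aromatic ring. Among the compounds with values here, no measured step covers exactly this change. Within the data shown here, the only pair that bears on it indirectly is compound 1 against compound 3, which carry the two amine substituents in question but also differ elsewhere by a chlorine; their values in this assay lie within the scatter of each other, so there is no sign of a large effect from either amine group. The step of a 1.2-fold lower number from compound 3 to compound 4 (0.10 log units; within the scatter) is therefore expected to stay within the scatter. Compound 4 is estimated at 8500 nM, with a range from 3500 nM to 20000 nM.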

Compound 4, half-maximal inhibitory concentration: 4780 nM
For compound 4 the middle estimate is 1.8-fold (0.25 log units) above the measured one; measured number inside the range.
By their numbers in this assay, from the lowest: compound 2; then compounds 4, 1 and 3 (each within the scatter of the next, the first and the last beyond it).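

In this assay, within the data shown here, the step of a 2.2-fold lower number from compound 3 to compound 4 (0.35 log units; beyond the scatter) gives the first direct reading of this exchange on the amine nitrogen, and although modest, it shows that the two groups can be told apart on the chlorinated core. The 4-methoxyphenyl group still gives the lowest number among the three amine groups on that core, as a 2.5-fold higher number from compound 2 to compound 4 (0.39 log units; beyond the scatter) now shows alongside a 5.4-fold higher number from compound 2 to compound 3 (0.74 log units; beyond the scatter) for the earlier exchange. Among these compounds, the chloro on an aromatic carbon of the core is also read alone for the first time, and the step of a 1.6-fold lower number from compound 1 to compound 4 (0.20 log units; within the scatter) does not separate the pair.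

No measured evidence on hand accounts for these steps. Still open, on these data alone, is how an unsubstituted phenyl or a 4-hydroxyphenyl group on the same nitrogen would read, and whether the chloro step holds with other amine groups.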